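Nitro in Place of Methoxy at the Assay Limit

The source may hold more compounds than are shown below. What is called first, only, known or untested is meant among the compounds shown, and "the series" means these compounds.

Measured compounds in a functional assay on ECa-109 cells (Homo sapiens) for cytotoxicity, read by MTT assay, with a stated time of 48 h; on this read-out lower numbers stand for stronger inhibition and higher numbers for weaker inhibition:
- compound 1 `COc1ccc(-c2c[nH]c(=O)n2-c2cc(OC)c(OC)c(OC)c2)cc1[N+](=O)[O-]`: > 50000 nM, a limit
- compound 2 `COc1ccc(-c2cn(C(C)=O)c(=O)n2-c2cc(OC)c(OC)c(OC)c2)cc1`: > 50000 nM, a limit
- compound 3 `COc1ccc(-c2cn(C(C)=O)c(=O)n2-c2cc(OC)c(OC)c(OC)c2)cc1OC`: > 50000 nM, a limit

Compound 3 has no exact number in this assay: its > 50000 nM is only a limit. In fact, the whole set sits at the limit of > 50000 nM in this assay, at which 3 of the 3 values shown sit.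

The next compound, compound 4 `COc1ccc(-c2cn(C(C)=O)c(=O)n2-c2cc(OC)c(OC)c(OC)c2)cc1[N+](=O)[O-]`, differs from compound 3 at one place: nitro in place of methoxy on an aromatic carbon. The group that enters lies ortho to a methoxy group.

Among the measured compounds shown here, the only measured step between close neighbours is a step that the two limits leave unreadable from compound 2 to compound 3, so it gives no size to carry over. Compound 1 also carries a nitro group in that place. Its > 50000 nM is again a limit.

With no readable step and no number to start from, no clear shift in either direction is expected in this assay, and compound 4 will most likely report a limit too. The expected change is a number no higher from compound 3 to compound 4 (the limit leaves the size open). For compound 4 the estimate is 50000 nM, with an expected range from 15000 nM to 100000 nM.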

Compound 4, half-maximal inhibitory concentration: 30800 nM
The estimate for compound 4 lay 1.6-fold (0.21 log units) above the measured number; low and high end bracket the measured number.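

In this assay, compound 4 is the only compound shown with an exact number, while the other three stay at a limit: the limit of > 50000 nM in this assay, at which 3 of the 4 values shown sit.

Nitro on this aromatic carbon, ortho to a methoxy group, gives an at least 1.6-fold lower number from compound 3 to compound 4 (0.21 log units; that floor lies within the scatter), and nitro in place of hydrogen at the same carbon gives an at least 1.6-fold lower number from compound 2 to compound 4 (0.21 log units; that floor lies within the scatter). Acetyl in place of hydrogen on an aromatic nitrogen gives an at least 1.6-fold lower number from compound 1 to compound 4 (0.21 log units; that floor lies within the scatter), so among these compounds a readable number appears only where nitro and acetyl occur together.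

From the compounds shown here alone, each of these steps is only a floor, so the true distance from compound 4 to its neighbours stays open. The compounds shown also do not tell whether an amine or a carboxylic acid at this place, or a longer chain in place of the acetyl, would give a readable number.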